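Cyano in place of acetyl on the aromatic ring

The source may hold more compounds than are shown below. What is called first, only, known or untested is meant among the compounds shown, and "the series" means these compounds.

For the measured compounds named here, in an assay on membranes from brain (strain Sprague-Dawley) for displacement of a labelled ligand from metabotropic glutamate receptor 5 (Rattus norvegicus), read by scintillation counting, with a stated time of 60 min (on this read-out lower numbers stand for stronger inhibition and higher numbers for weaker inhibition), compound 3 `CC(=O)c1cccc(C#Cc2cc(F)cc(C#N)c2)n1` gives 64 nM, one of only two numbers measured; the other belongs to compound 2 `N#Cc1cc(F)cc(C#Cc2cccc(F)n2)c1` with 41 nM, and the step of a 1.6-fold higher number from compound 2 to compound 3 (0.19 log units; within the scatter) stays within the scatter. Compound 1 `N#Cc1cccc(C#Cc2cc(F)cc(C(N)=O)c2)n1` reaches only the limit > 10000 nM in this assay, a limit and not a number (the limit of > 10000 nM in this assay, at which 1 of the 3 values shown sits). Compound 4 `N#Cc1cc(F)cc(C#Cc2cccc(C#N)n2)c1` differs from compound 3 by cyano in place of acetyl on an aromatic carbon. Going by the values given here, the only measured step at that position, from fluoro to acetyl, was the one just named and lay within the scatter, so compound 4 is expected to show no step beyond the scatter in this assay, a 1.4-fold lower number from compound 3 to compound 4 (0.15 log units; within the scatter). Compound 4 is therefore estimated at 45 nM, within a range from 15 nM to 140 nM.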

Compound 4, inhibition constant: 2.7 nM
Beside the measured number, compound 4's estimate is 17-fold (1.22 log units) above it; measured number below the stated range.
By their numbers in this assay, from the lowest: compound 4; then compounds 2 and 3 (each within the scatter of the next). At a limit, above all of these: compound 1.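

In this assay cyano next to the ring nitrogen stands clearly apart from both other groups, with a 24-fold lower number from compound 3 to compound 4 (1.37 log units; beyond the scatter) and a 15-fold lower number from compound 2 to compound 4 (1.18 log units; beyond the scatter) as its steps. This position therefore responds to the group placed on it, which the fluoro and acetyl pair alone had not shown. On another aromatic carbon, cyano in place of carbamoyl gives an at least 3700-fold lower number from compound 1 to compound 4 (3.56 log units; beyond the scatter), a step read against a limit: the limit of > 10000 nM in this assay, at which 1 of the 4 values shown sits.

On these data alone, whether an amine, a carboxylic acid or a longer chain at this position would keep the low number stays open. For the compounds shown here, with only three groups compared here, the data cannot tell what sets cyano apart.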